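Trading propyl for vinyl on a saturated chain

The source may report more compounds than this note shows. Statements on the series, on what has been measured and on what is new or still open speak of the compounds shown alone.

Three measured compounds share one core and differ only in a saturated chain attached through a carbonyl. In a functional assay on MDA-MB-231 cells (Homo sapiens) for cytotoxicity, read by MTT assay, with a stated time of 24 h (a higher number here means a weaker inhibitor, a lower number a stronger inhibitor), compound 1 `CCCCCCCCCCCCCCCCCC(=O)Nc1nnc(S[C@@H]2O[C@H](CO)[C@H](O)[C@H](O)[C@H]2O)s1` gives 67100 nM. Compound 2 `CCCCCCCC(=O)Nc1nnc(S[C@@H]2O[C@H](CO)[C@H](O)[C@H](O)[C@H]2O)s1` gives 30800 nM, and compound 3 `CCCCCCCCCCCC(=O)Nc1nnc(S[C@@H]2O[C@H](CO)[C@H](O)[C@H](O)[C@H]2O)s1` gives 32000 nM. Compound 3 therefore sits level with compound 2, and both have lower numbers than compound 1, making them somewhat stronger inhibitors.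

Compound 4 `C=CCCCCCCCCC(=O)Nc1nnc(S[C@@H]2O[C@H](CO)[C@H](O)[C@H](O)[C@H]2O)s1` differs from compound 3 in one place: vinyl in place of propyl on a saturated chain carbon, eight bonds along the chain from a carbonyl carbon. In words, this is vinyl in place of propyl on a saturated chain carbon, eight bonds along the chain from a carbonyl carbon.

For the measured compounds named here, no measured compound carries a double bond, so that part of the change is untested. Going by the values given here, the only guidance comes from steps in the saturated chain. The step of a 1.0-fold higher number from compound 2 to compound 3 (0.02 log units; within the scatter) stays within the scatter, while the steps of a 2.1-fold lower number from compound 1 to compound 3 (0.32 log units; beyond the scatter) and a 2.2-fold lower number from compound 1 to compound 2 (0.34 log units; beyond the scatter) are modest and involve much larger changes in the chain. The change here is small by comparison, so no shift beyond the scatter is expected in this assay. The expected step is a 1.1-fold lower number from compound 3 to compound 4 (0.03 log units; within the scatter). For compound 4, the estimated value is 30000 nM, with an expected range of 16000 nM to 55000 nM.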

Compound 4, half-maximal inhibitory concentration: 80600 nM
Compound 4: the middle estimate sits 2.7-fold (0.43 log units) below what was measured; the whole stated range lies below it.
By their numbers in this assay, from the lowest: compounds 2 and 3 (each within the scatter of the next); then compounds 1 and 4 (each within the scatter of the next).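

In this assay, this place in the chain proves sensitive to a small edit: vinyl in place of propyl, eight bonds along the chain from a carbonyl carbon, gives a 2.5-fold higher number from compound 3 to compound 4 (0.40 log units; beyond the scatter), a modest step but one beyond the scatter. Compound 4 also separates from compound 2, with a 2.6-fold higher number from compound 2 to compound 4 (0.42 log units; beyond the scatter), yet it stays level with compound 1, with a 1.2-fold higher number from compound 1 to compound 4 (0.08 log units; within the scatter), so the two compounds with the higher numbers carry very different chains, and chain length alone does not sort these four compounds. For the compounds shown here, the earlier compounds held only saturated chains, so this is the first sign that a swap of so few atoms, one that adds a double bond, can matter as much here as the much larger chain changes did, although nothing available explains the shift.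

The compounds shown leave open whether the step follows the double bond or the loss of one carbon, a question that an ethyl group at this place would help to separate. They also leave open whether a carboxylic acid or an amine carried on the same chain would shift the number in either direction.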